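A few compounds are considered here, and "the series" means these few. Any claim that something is new, unique, unknown or untested is made for them only; others in the source may bear on it.

Measured compounds:
Compound 1 `CCN1CCN(CCNC(=O)n2c(=O)n(C(C)C)c3ccccc32)CC1` gives 104 nM in an assay on isolated protein (striatum) for binding affinity to 5-hydroxytryptamine receptor 4 (Cavia porcellus), read by radioligand binding; a lower number here means a stronger inhibitor, a higher number a weaker inhibitor.
Compound 2 `CCn1c(=O)n(C(=O)NCCN2CCN(C)CC2)c2ccccc21` gives 75.4 nM in this assay.
Compound 3 `CCCN1CCN(CCNC(=O)n2c(=O)n(C(C)C)c3ccccc32)CC1` gives 87.3 nM in this assay.

Compound 3 differs from compound 1 by methyl in place of hydrogen on a saturated chain carbon, two bonds along the chain from an amine nitrogen in a ring, and in this assay this gave a 1.2-fold lower number from compound 1 to compound 3 (0.08 log units; within the scatter). Compound 4 `CCCn1c(=O)n(C(=O)NCCN2CCN(C)CC2)c2ccccc21` differs from compound 2 by methyl in place of hydrogen on a saturated chain carbon, two bonds along the chain from an aromatic nitrogen. The difference between the core of compound 1 and the core of compound 2 is not broken down here. The two changes are the same kind of change, not the same: in compound 3 the new methyl sits two bonds along the chain from an amine nitrogen in a ring, whereas in compound 4 it sits two bonds along the chain from an aromatic nitrogen. For compound 4 a small step of about a 1.2-fold lower number from compound 2 to compound 4 (0.06 log units; within the scatter) is expected, because a 1.2-fold lower number from compound 1 to compound 3 (0.08 log units; within the scatter) stayed within the scatter. Compound 4 is therefore estimated at 65 nM, expected between 30 nM and 140 nM.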

Compound 4, inhibition constant: 253 nM
Compound 4: middle estimate off by 3.9-fold (0.59 log units), on the low side; the measured number lies above the stated range.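

Adding a methyl to a saturated chain carbon gives a 3.4-fold higher number from compound 2 to compound 4 (0.53 log units; beyond the scatter), so in this assay the result of this kind of change did not carry over from one core to the other: the same change on two cores in this assay, a 1.2-fold lower number (0.08 log units; within the scatter) from compound 1 to compound 3 and a 3.4-fold higher number (0.53 log units; beyond the scatter) from compound 2 to compound 4, 4.0-fold (0.60 log units) apart, beyond the scatter of two such steps. A small step on one core is therefore no safe guide to the step on another core in this series. This pair of steps does not show why they differ, since the cores differ and the new methyl sits two bonds along the chain from an amine nitrogen in a ring in one case and from an aromatic nitrogen in the other.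

The compounds shown leave open how a longer chain, such as butyl, on the aromatic nitrogen of the core of compound 2 would behave. They also leave open whether the same methyl step on the amine nitrogen chain of that core would stay small.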